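Ethylcarbamoyl replaces acetyl in a series without numbers

The compounds below may be only part of what the source reports. "The series", "measured", "known", "first", "only" and "open" are said of these compounds alone.

In a functional assay on HT-29 cells (Homo sapiens) for cytotoxicity (on this read-out lower numbers stand for stronger inhibition and higher numbers for weaker inhibition), compound 1 (`CC(=O)Nc1[nH]nc2nnc(-c3ccccc3)c(-c3ccccc3)c12`) gives > 100000 nM as a limit of the assay, not a number. Compound 2 (`Nc1nn(Cc2ccccc2)c2nnc(-c3ccccc3)c(-c3ccccc3)c12`) gives > 100000 nM as a limit too. Compound 3 (`Nc1[nH]nc2nnc(-c3ccc(-c4ccccc4)cc3)c(-c3ccc(-c4ccccc4)cc3)c12`) gives > 100000 nM as a limit as well. The whole picture so far is the limit of > 100000 nM in this assay, at which 3 of the 3 values shown sit, and so none of these compounds has a true potency to compare.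

Compound 4 (`CCNC(=O)Nc1[nH]nc2nnc(-c3ccccc3)c(-c3ccccc3)c12`) has not yet been measured. Its difference from compound 1 (ethylamino in place of methyl on a carbonyl carbon) puts ethylamino in place of methyl on a carbonyl carbon, turning acetamido into (ethylcarbamoyl)amino.

Compound 1 at > 100000 nM offers only a limit to step from, so no step beyond the usual scatter is expected in this assay for this change. The expected step is an at least 1.2-fold lower number from compound 1 to compound 4 (0.09 log units; that floor lies within the scatter) and it remains an estimate. For compound 4 the estimated value is 80000 nM with an expected range from 25000 nM to 100000 nM and a reading at the limit of the assay is the likeliest outcome.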

Compound 4, half-maximal inhibitory concentration: > 100000 nM
Compound 4 was reported as a limit; the forecaster's own chance of this, stated with the estimate: 75%; at least 1.2-fold (0.09 log units) between middle value and limit.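

In this assay, for the compounds shown here, compound 1 and compound 4 each give a limit of the assay rather than a number, so no step between them can be read: the limit of > 100000 nM in this assay, at which 4 of the 4 values shown sit.

The compounds shown leave open whether ethylamino in place of methyl on a carbonyl carbon changes potency at all.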